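Ester aryl swap on the saturated ring carbon

This account rests on a few compounds, and the source may have more. Where it says the series, first, only, none or still open, it means among the compounds named here.

Compound 1 `O=C(NC1CCC(CN2CCN(c3cc(=O)c4cc(C(F)(F)F)cc([N+](=O)[O-])c4s3)CC2)CC1)c1ccccc1` carries a benzamido group. In an ADME assay on cells (Hepatocyte, Mus musculus) for metabolic stability (on this read-out higher numbers stand for a longer-lived compound and lower numbers for a shorter-lived compound), compound 1 gives only a limit of the assay, > 1.55 h. Compound 2 `O=C(OC1CCC(CN2CCN(c3cc(=O)c4cc(C(F)(F)F)cc([N+](=O)[O-])c4s3)CC2)CC1)c1ccncc1` places ((pyridin-4-yl)carbonyl)oxy in place of benzamido on a saturated ring carbon, and in this assay compound 2 gives 0.0817 h. Going by the values given here, that is the only plain number among the values shown; the other entry is a limit, (the limit of > 1.55 h in this assay, at which 1 of the 2 values shown sits). The step between them reads an at least 18-fold lower number from compound 1 to compound 2 (1.27 log units; beyond the scatter).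

Compound 3 `O=C(OC1CCC(CN2CCN(c3cc(=O)c4cc(C(F)(F)F)cc([N+](=O)[O-])c4s3)CC2)CC1)c1cccs1` differs from compound 2 by thiophen-2-yl in place of pyridin-4-yl on a carbonyl carbon; cut one bond further out, the change reads (pyridin-4-yl)carbonyl to (thiophen-2-yl)carbonyl. Among the compounds with values here, no measured step compares two aryl groups on the same carbonyl carbon. Within the data shown here, the only measured step, an at least 18-fold lower number from compound 1 to compound 2 (1.27 log units; beyond the scatter), concerns the exchange of benzamido for ((pyridin-4-yl)carbonyl)oxy, and the oxygen next to a carbonyl group is kept in both compound 2 and compound 3. The step of a 1.0-fold lower number from compound 2 to compound 3 (0.01 log units; within the scatter) is therefore expected to stay within the scatter, with no direction assumed. Compound 3 is estimated at 0.08 h in this assay, with a range of 0.03 h to 0.25 h.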

Compound 3, half-life: 0.0867 h
For compound 3 the middle estimate is 1.1-fold (0.03 log units) below the measured one; the range from low to high includes it.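

Exchanging pyridin-4-yl for thiophen-2-yl on a carbonyl carbon leaves the half-life in this assay within the scatter: a 1.1-fold higher number from compound 2 to compound 3 (0.03 log units; within the scatter). The large gap to the benzamido compound therefore holds with a second aromatic ring on the ester, and it is not confined to the pyridin-4-yl ester: an at least 17-fold lower number from compound 1 to compound 3 (1.25 log units; beyond the scatter). The entry for compound 1 in this comparison is a limit of the assay, and the size of the gap is read with that in view: the limit of > 1.55 h in this assay, at which 1 of the 3 values shown sits.

Compound 1 differs from compound 2 and compound 3 both in the link to the saturated ring carbon and in the aromatic ring on the carbonyl, so the compounds shown do not separate the ester oxygen from the ring; a phenyl ester or a thiophen-2-yl amide would divide the two changes. Also open, as far as these compounds go, is how the half-life reads with a non-aromatic group on the same carbonyl carbon, such as a short alkyl chain or a cyclohexyl ring, or with a carbamate as the link.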